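Nitro on the phenyl of compound 2

This account rests on a few compounds, and the source may have more. Where it says the series, first, only, none or still open, it means among the compounds named here.

In a functional assay on HT-29 cells (Homo sapiens) for antiproliferative activity, read by MTT assay, with a stated time of 96 h (on this read-out higher numbers stand for weaker inhibition and lower numbers for stronger inhibition), compound 1 (`O=C1NNC(=O)C2(CSC3=C2C(=O)c2ncccc2C3=O)N1`) gives 1580 nM; 1600 nM; 1600 nM (3 entries) as its value, and its repeat entries agree closely (the several entries of compound 1 in this assay, 1580 nM; 1600 nM; 1600 nM (3 entries)). In this assay compound 3 (`O=C1NN(c2ccc(Cl)cc2)C(=O)C2(CSC3=C2C(=O)c2ncccc2C3=O)N1`) gives 220 nM as its single entry. Compound 2 (`O=C1C2=C(C(=O)c3ncccc31)C1(CS2)NC(=O)N(c2ccccc2)C1=O`) gives 2 nM and holds the lowest number of the set. The gap from compound 2 to compound 3, its nearest neighbour on the numbers, lies beyond the scatter.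

Compound 4 (`O=C1C2=C(C(=O)c3ncccc31)C1(CS2)NC(=O)N(c2ccc([N+](=O)[O-])cc2)C1=O`) keeps everything in compound 2 except for one change, phenyl to 4-nitrophenyl, with nitro in place of hydrogen on an aromatic carbon, para to a large group (nitro in place of hydrogen on an aromatic carbon). Within the data shown here, no two measured compounds differ in one place only, so this step has no direct precedent and the expectation is loose.

A modest move toward weaker inhibition is expected in this assay and it may only just clear the scatter. The direction rests on compound 2, which at 2 nM already sits at the low end of the numbers. The expected size is a 3.0-fold higher number from compound 2 to compound 4 (0.48 log units; beyond the scatter) on this estimate. For compound 4 the estimated value is 6 nM with an expected range from 1 nM to 50 nM as its bounds.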

Compound 4, half-maximal inhibitory concentration: 250 nM
Compound 4: the middle estimate sits 42-fold (1.62 log units) below what was measured; the measured number lies above the stated range.
By their numbers in this assay, from the lowest: compound 2; then compounds 3 and 4 (each within the scatter of the next).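

In this assay, the phenyl of compound 2 turns out to be a sensitive place: nitro in place of hydrogen on an aromatic carbon, para to a large group, gives a 130-fold higher number from compound 2 to compound 4 (2.10 log units; beyond the scatter). Among these compounds, this is the first single change that can be read, as the earlier compounds differ from one another in more than one place and showed only that compound 2, at 2 nM, held the lowest number; the step now shows that this low number does not survive this one substitution on the phenyl. The step is also far larger than the spread of the only repeated measurements shown, which agree closely: the several entries of compound 1 in this assay, 1580 nM; 1600 nM; 1600 nM (3 entries)

Whether the loss belongs to nitro itself or would follow any substituent at this place stays open, since a single group is shown there, and a methoxy group or an amine at the same place would begin to separate the two readings. The compounds also carry no measurement that explains the step, and one substituent at one place gives no trend across the phenyl ring.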